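Changing the Aryl Group: An Estimate for Compound 4

The compounds below may be only part of what the source reports. "The series", "measured", "known", "first", "only" and "open" are said of these compounds alone.

Compound 1, `CC(C(=O)N1CCN(c2ccccc2F)CC1)N1C(=O)CCC1=O`, in a functional assay on the whole organism (strain Swiss) with Mus musculus as the target, in the maximal electroshock model, with a stated time of 1 h, at a dose of 300 mg/kg by the intraperitoneal route (a higher number here means a stronger effect of the compound at the dose given, a lower number a weaker effect), gives 50%.
Compound 2, `CCC(C(=O)N1CCN(c2ccccc2F)CC1)N1C(=O)CCC1=O`, gives 50% in this assay.
Compound 3, `CC(C(=O)N1CCN(c2ccccc2C(F)(F)F)CC1)N1C(=O)CCC1=O`, gives 75% in this assay.

Compound 1 stands level with compound 2, the two together the lowest of the three numbers, while compound 3 lies above it by a number 25 percentage points higher from compound 1 to compound 3 (beyond the scatter). Compound 4, `CC(C(=O)N1CCN(c2cccc(Cl)c2)CC1)N1C(=O)CCC1=O`, differs from compound 1 by 3-chlorophenyl in place of 2-fluorophenyl on an amine nitrogen in a ring. Going by the values given here, only one measured step touches the same place, the group on the amine nitrogen in the ring: a number 25 percentage points higher from compound 1 to compound 3 (beyond the scatter), a modest rise, though with a different group entering. The other step, no change at the digits printed from compound 1 to compound 2 (within the scatter), concerns the chain and does not bear on this change. A small rise or no change beyond the scatter is therefore expected, a number 10 percentage points higher from compound 1 to compound 4 (within the scatter). Compound 4 is estimated at 60%, between 25% and 100%.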

Compound 4, a percentage reported as activity, at one dose (the size of the read-out at that dose, not a potency): 75%
Beside the measured number, compound 4's estimate is 15 percentage points below it; measured number inside the range.
By their numbers in this assay, from the lowest: compounds 1 and 2 (each within the scatter of the next); then compounds 3 and 4 (each within the scatter of the next).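

In this assay, going by these compounds alone, the swap of 2-fluorophenyl for 3-chlorophenyl on the amine nitrogen in the ring gives a number 25 percentage points higher from compound 1 to compound 4 (beyond the scatter) and so shows that this position responds to a second group, not only to the one in compound 3. Compound 3 at 75% and compound 4 at 75% print the same number, although their groups differ. No measured evidence here explains the rise.

As far as these compounds go, the halogen and its place on the phenyl changed together in this step, so their separate shares remain unknown. A 3-fluorophenyl, a 2-chlorophenyl or a plain phenyl group on the same nitrogen remains an open case.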